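Amine swap on the fused core: compound 2 to compound 3

This account rests on a few compounds, and the source may have more. Where it says the series, first, only, none or still open, it means among the compounds named here.

Working notes on a small set of three compounds. Within the data shown here, compound 1 `Nc1sc(-c2ccccc2)c(-c2ccc(Cl)cc2)c1C(=O)NC1CC1` is the only member with a measured number in a functional assay on PC-3 cells (Homo sapiens) for cytotoxicity, read by sulforhodamine B assay, with a stated time of 72 h; a higher number here means a weaker inhibitor, a lower number a stronger inhibitor; there compound 1 gives 17100 nM. Compound 2 `Clc1ccc(-c2sc3ncnc(NC4CC4)c3c2-c2ccc(Cl)cc2)cc1` carries a cyclopropylamino group on its fused core. In this assay compound 2 gives only a limit, > 50000 nM, and not a number; this is the limit of > 50000 nM in this assay, at which 1 of the 2 values shown sits. Nothing can be said about a step between compound 1 and compound 2, as no comparison between them is available; their values simply stand side by side.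

Compound 3 `Clc1ccc(-c2sc3ncnc(N4CCCCC4)c3c2-c2ccc(Cl)cc2)cc1` differs from compound 2 in one place: piperidin-1-yl in place of cyclopropylamino on an aromatic carbon. Among the measured compounds shown here, no measured step of this kind exists in the set, so the expectation rests on compound 2 alone, whose value in this assay is a limit, > 50000 nM. The step from compound 2 to compound 3 is expected to be a step that the limit leaves unreadable from compound 2 to compound 3, that is, no change beyond the scatter and most likely another limit. Compound 3 is estimated at 60000 nM, with a range from 20000 nM to 200000 nM.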

Compound 3, half-maximal inhibitory concentration: > 50000 nM
Compound 3: a limit, no number; the forecaster's own chance of this, stated with the estimate: 70%; the middle value does not contradict the limit.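

In this assay compound 3 gives > 50000 nM, a limit and not a number. Compound 2 also stands at a limit, so no step can be read between compound 2 and compound 3: the limit of > 50000 nM in this assay, at which 2 of the 3 values shown sit.

Left open is whether piperidin-1-yl in place of cyclopropylamino on an aromatic carbon shifts the value in this assay in either direction.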